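One Phosphate Fewer: What to Expect of Compound 4

The source may hold more compounds than are shown below. What is called first, only, known or untested is meant among the compounds shown, and "the series" means these compounds.

Four compounds share one core and differ in two places. Compound 1 `CCCSc1nc(=O)ccn1[C@@H]1O[C@H](COP(=O)(O)OP(=O)(O)O)[C@@H](O)[C@H]1O` and compound 2 `COc1nc(=O)ccn1[C@@H]1O[C@H](COP(=O)(O)OP(=O)(O)O)[C@@H](O)[C@H]1O` were tested in an in vitro functional assay on 1321-N1 cells for agonist activity at P2Y purinoceptor 4 (Homo sapiens), read by scintillation proximity assay and inositol phosphate accumulation; a higher number here means that more compound is needed for the effect, a lower number that less compound is needed. Compound 2 gives 4490 nM in this assay, and compound 1 gives 4900 nM. The change between the two is propylsulfanyl in place of methoxy on an aromatic carbon, and the step is a 1.1-fold higher number from compound 2 to compound 1 (0.04 log units; within the scatter).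

Compound 3 `COc1nc(=O)ccn1[C@@H]1O[C@H](COP(=O)(O)O)[C@@H](O)[C@H]1O` differs from compound 2 in the core, and that difference is a hydrogen atom in place of a group of 4 heavy atoms (3 oxygen, 1 phosphorus; no ring), on an oxygen. In this assay compound 3 reaches only the limit of the assay, > 100000 nM. This is the limit of > 100000 nM in this assay, at which 1 of the 3 values shown sits. The step is an at least 22-fold higher number from compound 2 to compound 3 (1.34 log units; beyond the scatter).

Compound 4 `CCCSc1nc(=O)ccn1[C@@H]1O[C@H](COP(=O)(O)O)[C@@H](O)[C@H]1O` has not yet been measured. It differs from compound 3 by propylsulfanyl in place of methoxy on an aromatic carbon, which is the same change that separates compound 2 from compound 1, at the same place. For compound 4 the estimated step is a step that the limit leaves unreadable from compound 3 to compound 4. This expectation rests on compound 2 and compound 1, where the same change gave a 1.1-fold higher number from compound 2 to compound 1 (0.04 log units; within the scatter). Since compound 3 already sits at the limit of this assay, the same small step applied there should leave compound 4 at that limit as well. Compound 4 is therefore expected to give about 150000 nM in this assay, most likely again as a limit rather than a number, with a range from 50000 nM to 600000 nM.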

Compound 4, half-maximal effective concentration: > 100000 nM
Compound 4: only a limit was reported (the forecaster's own chance of this, stated with the estimate: 85%); the middle value does not contradict the limit.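

In this assay compound 4 gives > 100000 nM, which is a limit of the assay and not a number. Removing the terminal phosphate from the propylsulfanyl compound gives an at least 20-fold higher number from compound 1 to compound 4 (1.30 log units; beyond the scatter), so the large rise in the number seen on the methoxy core also appears on the propylsulfanyl core, while the step between the two compounds with one phosphate fewer cannot be read. This shows that the direction of the change carries from one core to the other and that it is large on both, but it does not show that the two steps are equal in size: the same change on two cores in this assay, an at least 22-fold higher number (1.34 log units; beyond the scatter) from compound 2 to compound 3 and an at least 20-fold higher number (1.30 log units; beyond the scatter) from compound 1 to compound 4; the limit leaves it open whether they differ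

On these data alone, the exchange of methoxy for propylsulfanyl can therefore be followed only among the compounds with the longer phosphate chain, as the compounds with one phosphate fewer give no readable number: the limit of > 100000 nM in this assay, at which 2 of the 4 values shown sit. It remains open how an amine or a longer chain on the same aromatic carbon would behave, and whether a third phosphate on the chain would lower the number further for either the methoxy or the propylsulfanyl compound.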